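The compounds below may be only part of what the source reports. "The series", "measured", "known", "first", "only" and "open" are said of these compounds alone.

Measured compounds:
compound 1 `c1ccc2c(c1)ccn2-c1nc(N2CCNCC2)nc2ccccc12`: 4 ug/mL
compound 2 `c1ccc2c(c1)ccn2-c1nc(N2CCCCC2)nc2ccccc12`: 50 ug/mL
compound 3 `Cn1cc(-c2nc(N3CCNCC3)nc3ccccc23)c2ccccc21`: 50 ug/mL

In a functional assay on KB cells (Homo sapiens) for antiproliferative activity, read by MTT assay (on this read-out higher numbers stand for weaker inhibition and lower numbers for stronger inhibition), compound 3 gives 50 ug/mL, level with compound 2 at the digits reported; together they carry the highest numbers of the three. For the measured compounds named here, compound 1 sits far lower, with 4 ug/mL, and the only step that differs in one place, a 13-fold higher number from compound 1 to compound 2 (1.10 log units; beyond the scatter), is large. Compound 4 `CN1CCN(c2nc(-c3cn(C)c4ccccc34)c3ccccc3n2)CC1` has not been measured in this assay. It differs from compound 3 by methyl in place of hydrogen on an amine nitrogen in a ring.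

Going by the values given here, no measured pair shows this change. Among the compounds with values here, the one step available removes the ring nitrogen together with its hydrogen, while compound 4 keeps the nitrogen and loses only the hydrogen, so the step from compound 3 to compound 4 is expected to be small, within or only slightly beyond the scatter, and if anything toward a higher number: a 1.2-fold higher number from compound 3 to compound 4 (0.08 log units; within the scatter) is the expected step. Compound 4 is therefore estimated at 60 ug/mL, with a range from 25 ug/mL to 150 ug/mL.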

Compound 4, half-maximal inhibitory concentration: 50 ug/mL
Beside the measured number, compound 4's estimate is 1.2-fold (0.08 log units) above it; low and high end bracket the measured number.
By their numbers in this assay, from the lowest: compound 1; then compounds 2, 3 and 4 (each within the scatter of the next).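

In this assay the swap of piperazin-1-yl for 4-methylpiperazin-1-yl brings no change at the digits printed from compound 3 to compound 4 (within the scatter) and so shows that, in this pair, the hydrogen on the amine nitrogen in the ring can give way to methyl without a difference the read-out can resolve. The earlier step, a 13-fold higher number from compound 1 to compound 2 (1.10 log units; beyond the scatter) and a change of piperazin-1-yl to piperidin-1-yl, removed the ring nitrogen together with its hydrogen and could not separate the two, whereas this pair keeps the nitrogen and alters only what it carries. Nothing measured here bears on why the methyl leaves the number where it stands.

On these data alone, what the same methyl would do on compound 1, which gives 4 ug/mL and has far more room to lose, stays open. So does the outcome of a larger group on that nitrogen, such as benzyl, acetyl or a longer chain.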